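Acetoxymethyl to methoxymethyl: expected stability gain

A few compounds are considered here, and "the series" means these few. Any claim that something is new, unique, unknown or untested is made for them only; others in the source may bear on it.

Measured in an ADME assay on liver for metabolic stability, with Liver microsome (Homo sapiens) as the target, read by LC-MS, using microsomes and NADPH, with a stated time of 30 min, tested at 1 uM; on this read-out lower numbers stand for a less stable compound and higher numbers for a more stable compound:
- compound 1 `Cc1cc(CCC#N)cc(C)c1Oc1cc(Nc2ccc(C#N)cc2)c(N)cc1C(=O)N(C)C`: 72.2%
- compound 2 `Cc1cc(CCC#N)cc(C)c1Oc1cc(Nc2ccc(C#N)cc2)c(N)cc1C(=O)NC1CC1`: 63.2%
- compound 3 `CC(=O)OCc1cc(N)c(Nc2ccc(C#N)cc2)cc1Oc1c(C)cc(CCC#N)cc1C`: 3%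

Compound 3 stands lowest of the three, beyond the scatter from both others. The next structure, compound 4 `COCc1cc(N)c(Nc2ccc(C#N)cc2)cc1Oc1c(C)cc(CCC#N)cc1C`, differs from it as follows: methyl in place of acetyl on an oxygen on a saturated carbon. In words, this is methyl in place of acetyl on an oxygen on a saturated carbon, or acetoxymethyl to methoxymethyl.

Going by the values given here, two measured steps bear on this change: a number 69.2 percentage points lower from compound 1 to compound 3 (beyond the scatter) and a number 60.2 percentage points lower from compound 2 to compound 3 (beyond the scatter). Both are large, and both bring in acetoxymethyl in place of a carbamoyl group. The remaining step, a number 9 percentage points lower from compound 1 to compound 2 (within the scatter), lies within the scatter and says little here. Among the compounds with values here, no measured compound carries methoxymethyl, so the acetyl is not isolated by any step so far.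

A rise in this assay is expected, though probably not the full distance to compound 1 at 72.2%. The expected step is a number 37 percentage points higher from compound 3 to compound 4 (beyond the scatter). The estimate for compound 4 is 40%, with an expected range of 15% to 70%.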

Compound 4, percent of the compound remaining: 90.8%
The estimate for compound 4 lay 50.8 percentage points below the measured number; the measured number lies above the stated range.
By their numbers in this assay, from the lowest: compound 3; then compounds 2 and 1 (each within the scatter of the next); then compound 4.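

In this assay, the methyl in place of acetyl on an oxygen on a saturated carbon gives a large step (a number 87.8 percentage points higher from compound 3 to compound 4 (beyond the scatter)), so the low number of compound 3 goes with the acetyl and not with the absence of a carbamoyl group on the aromatic carbon. A carbamoyl group is also not required for a high number here, as methoxymethyl gives modest steps up from both amides (a number 27.6 percentage points higher from compound 2 to compound 4 (beyond the scatter)) and (a number 18.6 percentage points higher from compound 1 to compound 4 (beyond the scatter)). Nothing measured here gives a reason for these steps.

Still open, as far as these compounds go, is whether the high number needs the methyl ether at all, or whether hydroxymethyl or ethoxymethyl would match it. An aminomethyl group or a longer chain on the same aromatic carbon would show how much of the change the ether oxygen carries.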